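This account rests on a few compounds, and the source may have more. Where it says the series, first, only, none or still open, it means among the compounds named here.

Compound 1 `Cc1ccc(C(=O)Nc2cc3nc(C4CCCCC4)[nH]c3cc2N(C)C)cc1` gives > 100 ug/mL in an ADME assay on Vero cells (Chlorocebus sabaeus) for cytotoxicity, read by resazurin assay, with a stated time of 3 days (a higher number here means a weaker inhibitor, a lower number a stronger inhibitor), which is a limit of the assay rather than a number.
Compound 2 `CN(C)c1cc2[nH]c(C3CCCCC3)nc2cc1NC(=O)c1ccc(F)cc1` gives > 100 ug/mL in this assay, again a limit.
Compound 3 `CN(C)c1cc2[nH]c(C3CCCCC3)nc2cc1NC(=O)c1ccc(OC(F)F)cc1` gives > 100 ug/mL in this assay, also a limit.

Within the data shown here, compound 3 therefore stands at the limit of > 100 ug/mL in this assay, at which 3 of the 3 values shown sit, and no measured compound sits anywhere else. The three steps among them, a step that the two limits leave unreadable from compound 1 to compound 2, a step that the two limits leave unreadable from compound 1 to compound 3 and a step that the two limits leave unreadable from compound 2 to compound 3, cannot be sized, since each ends at a limit on both sides.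

Compound 4 `CN(C)c1cc2[nH]c(C3CCCCC3)nc2cc1NC(=O)OCC(F)(F)F` differs from compound 3 at the carbonyl carbon: 2,2,2-trifluoroethoxy in place of 4-(difluoromethoxy)phenyl on a carbonyl carbon. The measured steps all concern changes on the aromatic ring that leaves here, and none of them yields a readable size, so they give no direction for this change. With every measured value sitting at the limit, the expectation for compound 4 is that it too reaches the limit, and the estimated step of a number no higher from compound 3 to compound 4 (the limit leaves the size open) is one of no real size. Compound 4 is thus estimated at 100 ug/mL, within a range of 40 ug/mL to 250 ug/mL.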

Compound 4, half-maximal inhibitory concentration: > 100 ug/mL
Compound 4 ended at the assay's limit; the forecaster's own chance of this, stated with the estimate: 75%; the middle value sits exactly at the limit.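

Compound 4 sits at the same assay limit as compound 1, compound 2 and compound 3, so none of the steps to compound 4 can be read: the limit of > 100 ug/mL in this assay, at which 4 of the 4 values shown sit.

The compounds shown leave open what actual number lies behind the limit for each, and so whether any of these changes alters the reading in this assay at all.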